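From Methyl to (Dimethylamino)methyl: What Compound 4 May Show

The source may hold more compounds than are shown below. What is called first, only, known or untested is meant among the compounds shown, and "the series" means these compounds.

Measured in an assay on COS-7 cells for inhibition of patatin-like phospholipase domain-containing protein 2 (Mus musculus), tested at 200 uM; on this read-out higher numbers stand for more inhibition at the one concentration tested (going by the name of the read-out) and lower numbers for less inhibition:

Compound 1 `CCOC(=O)c1cccc(-c2ccc(OCC)cc2)c1` gives 87%.
Compound 2 `CCOC(=O)c1cccc(-c2ccc(O)cc2)c1` gives 77%.
Compound 3 `CCOC(=O)c1cccc(-c2ccc(C)cc2)c1` gives 63%.

Compound 3 stands lowest of the three numbers: the step of a number 24 percentage points lower from compound 1 to compound 3 (beyond the scatter) and the step of a number 14 percentage points lower from compound 2 to compound 3 (beyond the scatter) both lie beyond the scatter, while the step of a number 10 percentage points lower from compound 1 to compound 2 (within the scatter) does not. Compound 4 `CCOC(=O)c1cccc(-c2ccc(CN(C)C)cc2)c1` has not yet been tested in this assay. It differs from compound 3 in one place: dimethylamino in place of hydrogen on a saturated chain carbon bound to an aromatic carbon.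

Among the measured compounds shown here, none of the measured steps puts a dimethylamino group onto that chain carbon; the three steps show only that an ethoxy or a hydroxy on the aromatic carbon gives a higher number than a methyl there. The measured steps give no guide to the direction of this new change, so for compound 4 the expected step is a number 3 percentage points lower from compound 3 to compound 4 (within the scatter), centred near no change but with a wide spread. Compound 4 is therefore estimated at 60%, in a range from 35% to 85%.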

Compound 4, a percentage reported as inhibition, at one concentration (the size of the read-out at that concentration, not a potency): 67%
Beside the measured number, compound 4's estimate is 7 percentage points below it; the range from low to high includes it.
By their numbers in this assay, from the lowest: compounds 3, 4, 2 and 1 (each within the scatter of the next, the first and the last beyond it).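

The first new step reads a number 4 percentage points higher from compound 3 to compound 4 (within the scatter) in this assay, so the saturated chain carbon bound to an aromatic carbon can carry a dimethylamino group with no change that stands clear of the scatter. Set in place of hydroxy, (dimethylamino)methyl gives a number 10 percentage points lower from compound 2 to compound 4 (within the scatter), while in place of ethoxy it gives a number 20 percentage points lower from compound 1 to compound 4 (beyond the scatter), so of these groups only ethoxy stays clearly ahead of it. Nothing available explains these numbers.

Going by these compounds, whether a longer chain carrying the dimethylamino group, a morpholine in its place, or a carboxylic acid on that chain carbon would move the number remains open. On these data alone, with one tested concentration, how these compounds rank in potency also remains open.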